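Working notes: aryl swap on the shared core, whole-animal dosing

A few compounds are considered here, and "the series" means these few. Any claim that something is new, unique, unknown or untested is made for them only; others in the source may bear on it.

Measured so far:
compound 1, `O=C(N/N=C/c1ccc(F)cc1)Nc1cccc2ccccc12`, gives 300 mg/kg in a functional assay on the whole organism (strain Swiss albino) with Mus musculus as the target, with a stated time of 0.5 h; a higher number here means that more compound is needed for the effect, a lower number that less compound is needed
compound 2, `COc1cc(/C=N/NC(=O)Nc2cccc3ccccc23)ccc1O`, gives 300 mg/kg in this assay

Compound 1 stands level with compound 2 at the digits printed; the two values show no difference that lies beyond the scatter of this assay, so nothing about the direction of any change can be read from the pair. Both compounds carry the same core and differ only in the aryl group on the carbon with a double bond to nitrogen, and that difference leaves the minimum effective dose unchanged.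

Compound 3, `O=C(N/N=C/c1ccccc1Cl)Nc1cccc2ccccc12`, is not yet measured. It differs from compound 1 as follows: 2-chlorophenyl in place of 4-fluorophenyl on a carbon with a double bond to nitrogen. Going by the values given here, no step between two measured compounds shows what this kind of change does; the only comparison available, compound 1 against compound 2, shows two aryl groups giving the same dose. Given that compound 1 gives 300 mg/kg, the expectation for compound 3 is a step of no change at the digits printed from compound 1 to compound 3 (within the scatter) that stays within the scatter, with no clear direction. Compound 3 is therefore estimated at 300 mg/kg, in the range 150 mg/kg to 600 mg/kg.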

Compound 3, minimum effective dose: 300 mg/kg
Compound 3: middle estimate and measured number agree at the digits printed; low and high end bracket the measured number.
By their numbers in this assay, from the lowest: compounds 1, 2 and 3 (each within the scatter of the next).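

Placing 2-chlorophenyl in place of 4-fluorophenyl on a carbon with a double bond to nitrogen gives no change at the digits printed from compound 1 to compound 3 (within the scatter) in this assay, which is the first step between measured compounds at this position. This single step changes both the halogen and its printed location on the phenyl ring, yet the minimum effective dose stays level, so neither change, at least in this combination, separates the two compounds; a 2-chlorophenyl and a 4-fluorophenyl group are interchangeable here on the evidence of this one pair, and compounds 1, 2 and 3 now all print the same value. No data in hand bear on the reason for this result.

From the compounds shown here alone, all the aryl groups seen so far leave the reading flat, so it remains open whether an aryl group carrying an amine or a carboxylic acid, or a longer chain in place of the aryl group, would move the dose in this assay at all. Going by these compounds, it is equally open whether a change to the shared core itself, rather than at this position, would separate compounds.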